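Methoxy Addition in a Series Sitting at the Assay Limit

The compounds below may be only part of what the source reports. "The series", "measured", "known", "first", "only" and "open" are said of these compounds alone.

Compound 1, `C=C(C)[C@@H]1CC=C(Cn2cc(COc3ccc(C4NC(=O)NC(C)=C4C(=O)OCC)cc3)nn2)CC1`, in a functional assay on NCI/ADR-RES cells (Homo sapiens) for inhibition, read by sulforhodamine B assay, with a stated time of 48 h (on this read-out higher numbers stand for weaker inhibition of growth and lower numbers for stronger inhibition of growth), gives > 100000 nM.
Compound 2, `C=C(C)[C@@H]1CC=C(Cn2cc(COc3ccc(C4NC(=O)NC(C)=C4C(=O)OCC)cc3OC)nn2)CC1`, in this assay gives > 100000 nM.
Compound 3, `C=C(C)[C@@H]1CC=C(Cn2cc(COc3ccc(C4NC(=O)NC5=C4C(=O)CC(C)(C)C5)cc3)nn2)CC1`, in this assay gives > 100000 nM.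

Each of these three values is a limit of the assay, not a number. Compound 2 differs from compound 1 by methoxy in place of hydrogen on an aromatic carbon. The size of that step, a step that the two limits leave unreadable from compound 1 to compound 2, cannot be read because of the limit of > 100000 nM in this assay, at which 3 of the 3 values shown sit. Compound 3 carries another core; the difference between the cores of compound 1 and compound 3 is not broken down here. Compound 4, `C=C(C)[C@@H]1CC=C(Cn2cc(COc3ccc(C4NC(=O)NC5=C4C(=O)CC(C)(C)C5)cc3OC)nn2)CC1`, differs from compound 3 by methoxy in place of hydrogen on an aromatic carbon, the same change as from compound 1 to compound 2. Compound 4 is expected to show a step of a number no higher from compound 3 to compound 4 (the limit leaves the size open) in this assay. This expectation rests on compound 3, whose > 100000 nM is a limit, and on the unreadable step that the two limits leave unreadable from compound 1 to compound 2. Compound 4 is therefore estimated at 100000 nM, between 30000 nM and 300000 nM, most likely again reported only as a limit.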

Compound 4, concentration for total growth inhibition: > 100000 nM
Compound 4 ended at the assay's limit (the forecaster's own chance of this, stated with the estimate: 85%); the middle value lies on the limit itself.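

The size of the step from compound 3 to compound 4 cannot be read, because both values are limits and not numbers: the limit of > 100000 nM in this assay, at which 4 of the 4 values shown sit.

The compounds shown leave open whether methoxy in place of hydrogen on an aromatic carbon changes growth inhibition at all.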